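Aryl swap on the acrylamide chain: compound 3 to compound 4

The source may report more compounds than this note shows. Statements on the series, on what has been measured and on what is new or still open speak of the compounds shown alone.

The series shares a core carrying a trimethoxybenzoyl group and an acrylamide, and varies the aryl group on the double-bonded chain carbon. Compound 1 `COc1ccc(C(=O)c2cc(OC)c(OC)c(OC)c2)cc1NC(=O)/C=C/c1cc(OC)c(OC)c(OC)c1` gives 5200 nM in a functional assay on COLO 205 cells (Homo sapiens) for cytotoxicity, read by MTT assay, with a stated time of 72 h; a lower number here means a stronger inhibitor, a higher number a weaker inhibitor. Compound 2 `COc1cccc(/C=C/C(=O)Nc2cc(C(=O)c3cc(OC)c(OC)c(OC)c3)ccc2OC)c1` gives 5100 nM in this assay, and compound 3 `COc1ccc(C(=O)c2cc(OC)c(OC)c(OC)c2)cc1NC(=O)/C=C/c1cccc(OC(F)(F)F)c1` gives 7900 nM. Compound 3 has the highest of the three numbers, but both steps that reach it are within the scatter, a 1.5-fold higher number from compound 1 to compound 3 (0.18 log units; within the scatter) and a 1.5-fold higher number from compound 2 to compound 3 (0.19 log units; within the scatter), so no order among the three is established.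

Compound 4 `COc1ccc(C(=O)c2cc(OC)c(OC)c(OC)c2)cc1NC(=O)/C=C/c1ccc(F)c(F)c1` is not yet measured. It differs from compound 3 by 3,4-difluorophenyl in place of 3-(trifluoromethoxy)phenyl on a double-bonded chain carbon bound to a double-bonded chain carbon.

Two measured steps change the aryl group at this same place: a 1.0-fold lower number from compound 1 to compound 2 (0.01 log units; within the scatter) and a 1.5-fold higher number from compound 1 to compound 3 (0.18 log units; within the scatter). The third step, a 1.5-fold higher number from compound 2 to compound 3 (0.19 log units; within the scatter), alters only a methyl on a ring oxygen. All three are within the scatter, so the aryl group on the chain carbon has so far not moved the number beyond noise.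

Compound 4 is therefore expected to show no step beyond the scatter, a 1.3-fold lower number from compound 3 to compound 4 (0.12 log units; within the scatter). The estimate for compound 4 in this assay is 6000 nM, within a range from 3000 nM to 12000 nM.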

Compound 4, half-maximal inhibitory concentration: 6020 nM
Estimate against measurement, compound 4: 1.0-fold (0.00 log units) below; low and high end bracket the measured number.
By their numbers in this assay, from the lowest: compounds 2, 1, 4 and 3 (each within the scatter of the next).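

For the compounds shown here, compound 4 is the first whose aryl group on the double-bonded chain carbon carries no ring oxygen, since 3,4-difluorophenyl has 0 hydrogen-bond acceptors and only fluorine on the ring. Even so, this assay gives a 1.3-fold lower number from compound 3 to compound 4 (0.12 log units; within the scatter) and a 1.2-fold higher number from compound 2 to compound 4 (0.07 log units; within the scatter) and a 1.2-fold higher number from compound 1 to compound 4 (0.06 log units; within the scatter) with every one of these steps inside the noise. The aryl groups at this place can therefore differ in fluorine or oxygen substitution, from 3,4,5-trimethoxyphenyl to 3,4-difluorophenyl, without any step among compound 1, compound 2, compound 3 and compound 4 leaving the scatter, and nothing on hand explains this flat picture.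

From the compounds shown here alone, whether any group at this place can move the number beyond the scatter remains open, for example a phenyl carrying an amine or a carboxylic acid, or a longer chain between the amide carbonyl and the aryl group. Going by these compounds, all four compounds also share the trimethoxybenzoyl group and the rest of the core, so the effect of a change there on this assay is unknown.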